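This account rests on a few compounds, and the source may have more. Where it says the series, first, only, none or still open, it means among the compounds named here.

Working notes on the tetracyclic series around compound 1 `Cc1ccc2c(c1)C(C)(C)[C@H]1COc3ccc4c(=O)c(C)c(C)oc4c3[C@H]1N2`, compound 2 `Cc1oc2c3c(ccc2c(=O)c1C)OC[C@H]1[C@@H]3Nc2ccccc2C1(C)C` and compound 3 `COc1ccc2c(c1)C(C)(C)[C@H]1COc3ccc4c(=O)c(C)c(C)oc4c3[C@H]1N2`, all tested in a functional assay on MCF7 cells (Homo sapiens) for antiproliferative activity, read by MTT assay; on this read-out higher numbers stand for weaker inhibition and lower numbers for stronger inhibition.

In this assay compound 1 gives 94300 nM. For compound 2 only a limit of the assay is available, > 100000 nM. Compound 3 likewise reaches only a limit of the assay, > 100000 nM. The steps that can be read are an at least 1.0-fold higher number from compound 1 to compound 2 (0.02 log units; that floor lies within the scatter) and an at least 1.0-fold higher number from compound 1 to compound 3 (0.02 log units; that floor lies within the scatter); the comparison a step that the two limits leave unreadable from compound 2 to compound 3 cannot be sized, and the limit of > 100000 nM in this assay, at which 2 of the 3 values shown sit, is the reason the series gives so little to work with.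

Compound 4 `Cc1coc2c3c(ccc2c1=O)OC[C@H]1[C@@H]3Nc2ccccc2C1(C)C` is not yet measured. Relative to compound 2 the change is hydrogen in place of methyl on an aromatic carbon. For the measured compounds named here, none of the measured steps removes a methyl at this position; the two readable ones, which move between the aromatic carbon of the outer benzene ring, are floors that lie within the scatter. On that basis no step beyond the scatter is expected, and compound 4 is expected to remain near the limit of the assay: the estimate for compound 4 in this assay is 120000 nM, with a range from 50000 nM to 300000 nM. The expected step is therefore a step that the limit leaves unreadable from compound 2 to compound 4.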

Compound 4, half-maximal inhibitory concentration: 9600 nM
For compound 4 the middle estimate is 13-fold (1.10 log units) above the measured one, and the stated range ends above it.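

In this assay, for the compounds shown here, this is the first position where a single change clearly moves the read-out: hydrogen in place of methyl, on the aromatic carbon next to the ring oxygen, gives an at least 10-fold lower number from compound 2 to compound 4 (1.01 log units; beyond the scatter). The earlier steps shown here concerned a different position and were either floors within the scatter or could not be read, so they gave no sign that this methyl matters. The step is itself only a floor, and its full size cannot be read because compound 2 sits at a limit: the limit of > 100000 nM in this assay, at which 2 of the 4 values shown sit.

Going by these compounds, it remains open whether the same change holds when it is combined with the methyl of compound 1 or the methoxy of compound 3. On these data alone, it is also open how this carbon responds to a longer chain such as ethyl, or to an amine, and what happens when the methyl group ortho to it is changed.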